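From 2-Methoxyethyl to 4-Methoxycyclohexyl on the Shared Core

The source may report more compounds than this note shows. Statements on the series, on what has been measured and on what is new or still open speak of the compounds shown alone.

In an ADME assay on S9 fraction from liver (Homo sapiens) for metabolic stability, with a stated time of 60 min (on this read-out lower numbers stand for a less stable compound and higher numbers for a more stable compound), compound 1 `Cc1nc(-c2nc[nH]n2)ccc1-c1cnc2c(n1)N([C@H]1CC[C@H](O)CC1)C(=O)CN2` gives 97%, and compound 2 `COCCN1C(=O)CNc2ncc(-c3ccc(-c4nc[nH]n4)nc3C)nc21` gives 100%. The two stand level, and compound 2 therefore sits at the top of the numbers only within the scatter. Compound 3 `CO[C@H]1CC[C@H](N2C(=O)CNc3ncc(-c4ccc(-c5nc[nH]n5)nc4C)nc32)CC1` differs from compound 2 by 4-methoxycyclohexyl in place of 2-methoxyethyl on an amide-type nitrogen in a ring, with 4-methoxycyclohexyl in place of 2-methoxyethyl on an amide-type nitrogen in a ring. Within the data shown here, one measured step bears on this: a number 3 percentage points higher from compound 1 to compound 2 (within the scatter), where 4-hydroxycyclohexyl gives way to 2-methoxyethyl on that same nitrogen. Among the measured compounds shown here, compound 1 thus carries a six-membered ring of carbon there and gives 97%, although no measured compound has the 4-methoxycyclohexyl group itself. Little movement in this assay is therefore expected, perhaps slightly downward. The estimated change is a number 7 percentage points lower from compound 2 to compound 3 (within the scatter), which is no step beyond the scatter. For compound 3 the expected value is 93%, with an estimated range of 76% to 100%.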

Compound 3, percent of the compound remaining: 82%
Compound 3: middle estimate off by 11 percentage points, on the high side; the measured number falls inside the stated range.
By their numbers in this assay, from the lowest: compound 3; then compounds 1 and 2 (each within the scatter of the next).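

In this assay this position proves sensitive to the group it carries: 4-methoxycyclohexyl in place of 2-methoxyethyl on the amide-type nitrogen gives a number 18 percentage points lower from compound 2 to compound 3 (beyond the scatter) on this read-out. The six-membered carbon ring alone does not go with the lower number, as compound 1 carries that ring and stands level with compound 2, whereas methyl in place of hydrogen on the oxygen of that ring gives a number 15 percentage points lower from compound 1 to compound 3 (beyond the scatter) in this comparison. Nothing available explains either step.

The compounds shown leave open whether the lower number is confined to the methyl ether on this ring. They also do not tell how a 4-aminocyclohexyl group, a 4-fluorocyclohexyl group or a longer ether chain would stand on this nitrogen.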